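The source may hold more compounds than are shown below. What is called first, only, known or untested is meant among the compounds shown, and "the series" means these compounds.

Measured in a functional assay on HepG2 cells (Homo sapiens) for antiproliferative activity, read by MTT assay, with a stated time of 24 h; on this read-out higher numbers stand for weaker inhibition and lower numbers for stronger inhibition:
- Compound 1 `C#CCOc1ccc2c(=O)c(-c3cc(OC)c(OC)cc3OC)coc2c1` gives 4950 nM
- Compound 2 `COc1cc(OC)c(-c2coc3cc(OCc4ccccc4C(F)(F)F)ccc3c2=O)cc1OC` gives 6550 nM
- Compound 3 `COc1cc(OC)c(-c2coc3cc(OCc4cccc(Cl)c4)ccc3c2=O)cc1OC` gives 750 nM

Compound 3 stands lowest of the three, with 750 nM. Compound 4 `COc1cc(OC)c(-c2coc3cc(OCc4ccc(C(F)(F)F)cc4)ccc3c2=O)cc1OC` differs from it in one place: 4-(trifluoromethyl)phenyl in place of 3-chlorophenyl on a saturated chain carbon bound to an oxygen on an aromatic ring. The closest evidence is an 8.7-fold lower number from compound 2 to compound 3 (0.94 log units; beyond the scatter), and a 6.6-fold lower number from compound 1 to compound 3 (0.82 log units; beyond the scatter) is of similar size, while a 1.3-fold higher number from compound 1 to compound 2 (0.12 log units; within the scatter). Among the measured compounds shown here, compound 2 is the only measured compound with a trifluoromethyl group, but as 2-(trifluoromethyl)phenyl rather than 4-(trifluoromethyl)phenyl, so this evidence is indirect. In this assay a modest rise in the number is therefore expected, smaller than those two larger steps. The expected change is a 2.7-fold higher number from compound 3 to compound 4 (0.43 log units; beyond the scatter). Compound 4 is estimated at 2000 nM, with an expected range of 500 nM to 7000 nM.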

Compound 4, half-maximal inhibitory concentration: 890 nM
Estimate against measurement, compound 4: 2.2-fold (0.35 log units) above, within the range that was stated.
By their numbers in this assay, from the lowest: compounds 3 and 4 (each within the scatter of the next); then compounds 1 and 2 (each within the scatter of the next).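

In this assay the step from 3-chlorophenyl to 4-(trifluoromethyl)phenyl is small, with a 1.2-fold higher number from compound 3 to compound 4 (0.07 log units; within the scatter) lying within the scatter, so a low number at this place is not limited to the chlorine-bearing ring. Where the trifluoromethyl group sits on the ring matters much more, as a 7.4-fold lower number from compound 2 to compound 4 (0.87 log units; beyond the scatter) shows, and a 5.6-fold lower number from compound 1 to compound 4 (0.75 log units; beyond the scatter) is of similar size. No measurement here accounts for these differences. Going by these compounds, whether 4-chlorophenyl would match these two compounds stays open, as does the effect of an amine or a carboxylic acid on this ring.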